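A Hydroxy Group Added to Compound 2

This account rests on a few compounds, and the source may have more. Where it says the series, first, only, none or still open, it means among the compounds named here.

Compound 1 `COc1ccc(-c2cncc3[nH]c(=O)n(Cc4cc(OC)c(OC)c(OC)c4)c23)cc1` reaches only a limit in a functional assay on A549 cells (Homo sapiens) for antiproliferative activity, read by MTT assay, with a stated time of 48 h (on this read-out lower numbers stand for stronger inhibition and higher numbers for weaker inhibition), > 20000 nM. For the measured compounds named here, compound 2 `COc1ccc(-c2cc3c(cn2)[nH]c(=O)n3-c2cc(OC)c(OC)c(OC)c2)cc1` gives 1120 nM in this assay, the only true number so far. Compound 3 `COc1ccc(-c2cc3c(cn2)[nH]c(=O)n3-c2cc(OC)c(OC)c(OC)c2)cc1O` differs from compound 2 by one change, hydroxy in place of hydrogen on an aromatic carbon, turning 4-methoxyphenyl into 3-hydroxy-4-methoxyphenyl. Going by the values given here, no measured step bears on this change, so the expectation remains a judgement: stronger inhibition beyond the scatter, an estimated 7.5-fold lower number from compound 2 to compound 3 (0.87 log units; beyond the scatter). For compound 3 the expected value is 150 nM, with an estimated range of 20 nM to 1000 nM.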

Compound 3, half-maximal inhibitory concentration: 630 nM
Compound 3: middle estimate off by 4.2-fold (0.62 log units), on the low side; low and high end bracket the measured number.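

For the compounds shown here, the step in this assay is a 1.8-fold lower number from compound 2 to compound 3 (0.25 log units; within the scatter) and gives the only reading so far of a change on this ring. A hydroxy ortho to a methoxy group is therefore tolerated at this position, with compound 2 and compound 3 level within the scatter. Nothing measured here gives a reason for this result. The compounds shown leave open whether an amine, a carboxylic acid or a longer chain such as ethoxy in the same place would also stay within the scatter of compound 2.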